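Same Aryl Swap, Second Core: Estimating Compound 4

The compounds below may be only part of what the source reports. "The series", "measured", "known", "first", "only" and "open" are said of these compounds alone.

Measured compounds:
compound 1, `Cc1cc(=O)n(-c2cccc(F)c2)nc1C(=O)Nc1ccc(Oc2ncnc3ccsc23)c(F)c1`, 9050 nM
compound 2, `Cc1ccc(-n2nc(C(=O)Nc3ccc(Oc4ncnc5ccsc45)c(F)c3)c(C)cc2=O)cc1`, 7250 nM
compound 3, `Cc1cc(=O)n(-c2cccc(F)c2)nc1C(=O)Nc1ccc(Oc2ncnc3sccc23)cc1`, 27200 nM

In a functional assay on MCF7 cells (Homo sapiens) for cytotoxicity, read by MTT assay, with a stated time of 72 h (a lower number here means a stronger inhibitor, a higher number a weaker inhibitor), compound 1 gives 9050 nM, and compound 2 gives 7250 nM. The change between them is 4-methylphenyl in place of 3-fluorophenyl on an aromatic nitrogen, and it made a step of a 1.2-fold lower number from compound 1 to compound 2 (0.10 log units; within the scatter). Compound 3, with a different core, gives 27200 nM in this assay; how its core differs from that of compound 1 is not broken down here.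

Compound 4, `Cc1ccc(-n2nc(C(=O)Nc3ccc(Oc4ncnc5sccc45)cc3)c(C)cc2=O)cc1`, has not yet been measured. It differs from compound 3 by 4-methylphenyl in place of 3-fluorophenyl on an aromatic nitrogen, the same change already seen from compound 1 to compound 2, at the same place. Since that earlier step was a 1.2-fold lower number from compound 1 to compound 2 (0.10 log units; within the scatter), the expected step from compound 3 to compound 4 in this assay is estimated as a 1.2-fold lower number from compound 3 to compound 4 (0.09 log units; within the scatter), a small move resting on a single precedent. Compound 4 is therefore expected to give about 22000 nM in this assay, estimated to lie between 10000 nM and 50000 nM.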

Compound 4, half-maximal inhibitory concentration: > 40000 nM
Compound 4 was reported as a limit (the forecaster's own chance of this, stated with the estimate: 10%); middle value at least 1.8-fold (0.25 log units) away from the limit.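

In this assay compound 4 gives > 40000 nM and this is a limit of the assay, not a number. Putting 4-methylphenyl in place of 3-fluorophenyl on the aromatic nitrogen therefore gives only a floor for the step, an at least 1.4-fold higher number from compound 3 to compound 4 (0.16 log units; that floor lies within the scatter) and the true step could be larger than that floor. This shows that the result on the second core can be stated only from one side, and it does not show whether the change behaves the same way on both cores or differently: the same change on two cores in this assay, a 1.2-fold lower number (0.10 log units; within the scatter) from compound 1 to compound 2 and an at least 1.4-fold higher number (0.16 log units; that floor lies within the scatter) from compound 3 to compound 4; the limit leaves it open whether they differ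

Only two aryl groups on that aromatic nitrogen appear here, both carbon-only rings with one small substituent, so a ring carrying an amine or a carboxylic acid remains untested in the compounds shown. As far as these compounds go, whether a longer chain on that nitrogen would give a value that can be read as a number on this core also stays open.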